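The compounds below may be only part of what the source reports. "The series", "measured", "known", "first", "only" and "open" are said of these compounds alone.

Measured compounds:

Compound 1, `CN1CCN(CCCCCCn2c3c(c4ccccc42)C(=O)c2c[n+]([O-])c4ccccc4c2C3=O)CC1`: 2400 nM
Compound 2, `O=C1c2c[n+]([O-])c3ccccc3c2C(=O)c2c1c1ccccc1n2CCCCN1CCCCC1`: 610 nM
Compound 3, `O=C1c2c[n+]([O-])c3ccccc3c2C(=O)c2c1c1ccccc1n2CCN1CCCC1`: 630 nM

In a functional assay on MDA-MB-231 cells (Homo sapiens) for cytotoxicity, read by MTT assay, with a stated time of 72 h (a higher number here means a weaker inhibitor, a lower number a stronger inhibitor), compound 3 stands second highest of the three numbers. Its neighbour is compound 2, and a 1.0-fold higher number from compound 2 to compound 3 (0.01 log units; within the scatter), so the two cannot be told apart. The farthest value belongs to compound 1, and a 3.8-fold lower number from compound 1 to compound 3 (0.58 log units; beyond the scatter), a modest but real gap.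

Compound 4, `CCCN1CCN(CCCCn2c3c(c4ccccc42)C(=O)c2c[n+]([O-])c4ccccc4c2C3=O)CC1`, differs from compound 3 in one place: 2-(4-propylpiperazin-1-yl)ethyl in place of pyrrolidin-1-yl on a saturated chain carbon, two bonds along the chain from an aromatic nitrogen. The change brings back a piperazine-bearing chain of the kind found in compound 1, though carried on a shorter linker and with a propyl rather than a methyl on the far nitrogen.

Within the data shown here, two measured steps bear on this. Removing such a chain gave a 3.8-fold lower number from compound 1 to compound 3 (0.58 log units; beyond the scatter) and, at the other attachment, a 3.9-fold lower number from compound 1 to compound 2 (0.59 log units; beyond the scatter). Putting one back would therefore be expected to raise the number, though perhaps less than fully, since the linker is shorter. The expected step is a 2.4-fold higher number from compound 3 to compound 4 (0.38 log units; beyond the scatter). For compound 4 the estimate in this assay is 1500 nM, with a likely range from 600 nM to 3500 nM.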

Compound 4, half-maximal inhibitory concentration: 2980 nM
Estimate against measurement, compound 4: 2.0-fold (0.30 log units) below; measured number inside the range.
By their numbers in this assay, from the lowest: compounds 2 and 3 (each within the scatter of the next); then compounds 1 and 4 (each within the scatter of the next).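

In this assay, the chain stays the same while piperidin-1-yl gives way to 4-propylpiperazin-1-yl, with a 4.9-fold higher number from compound 2 to compound 4 (0.69 log units; beyond the scatter), so the ring at the chain end can shift the number on its own, whereas every earlier pair also differed in chain length. The step of a 4.7-fold higher number from compound 3 to compound 4 (0.67 log units; beyond the scatter) is of similar size, while a 1.2-fold higher number from compound 1 to compound 4 (0.09 log units; within the scatter) leaves these two piperazine compounds indistinguishable, and among these four compounds both piperazines stand apart from the piperidine and pyrrolidine compounds, with none going against this. No measurement here explains this difference.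

As far as these compounds go, how a morpholin-4-yl ring or a piperazine with a bare far nitrogen would behave at this place remains open. Compounds 1 and 4 differ in both chain length and far-nitrogen group, so the effect of each alone is also unresolved.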